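Hydroxyphenyl in place of difluorophenyl on the pendant chain

A few compounds are considered here, and "the series" means these few. Any claim that something is new, unique, unknown or untested is made for them only; others in the source may bear on it.

In an in vitro assay on cells for displacement of a labelled ligand from thyroid hormone receptor beta (Homo sapiens), with a stated time of 48 h (a lower number here means a stronger inhibitor, a higher number a weaker inhibitor), compound 1 `Cc1cc(NC(=O)CC(=O)O)c2c(c1Oc1ccc(O)c(CCc3ccc(F)cc3)c1)CCC2` gives 8.2 nM, compound 2 `Cc1cc(NC(=O)CC(=O)O)c2c(c1Oc1ccc(O)c(CCc3ccc(F)cc3F)c1)CCC2` gives 12 nM and compound 3 `Cc1cc(NC(=O)CC(=O)O)c2c(c1Oc1ccc(O)c(CCc3ccccc3Cl)c1)CCC2` gives 30 nM. Compound 2 stands second highest of the three numbers; its gap to compound 1 is within the scatter, and to compound 3 it is a 2.5-fold higher number from compound 2 to compound 3 (0.40 log units; beyond the scatter). Compound 4 `Cc1cc(NC(=O)CC(=O)O)c2c(c1Oc1ccc(O)c(CCc3cccc(O)c3)c1)CCC2` differs from compound 2 by 3-hydroxyphenyl in place of 2,4-difluorophenyl on a saturated chain carbon, two bonds along the chain from an aromatic carbon. Going by the values given here, two measured steps bear on this: a 1.5-fold higher number from compound 1 to compound 2 (0.17 log units; within the scatter) and a 3.7-fold higher number from compound 1 to compound 3 (0.56 log units; beyond the scatter). Both changes to the pendant aryl moved the number upward, at most modestly. Among the compounds with values here, no measured step introduces a hydroxyl on this ring. Compound 4 is expected to move by a 1.7-fold higher number from compound 2 to compound 4 (0.22 log units; within the scatter). The estimate for compound 4 is 20 nM, with a range from 7 nM to 60 nM.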

Compound 4, inhibition constant: 81.3 nM
Compound 4: the middle estimate sits 4.1-fold (0.61 log units) below what was measured, outside the stated range (above it).
By their numbers in this assay, from the lowest: compounds 1 and 2 (each within the scatter of the next); then compound 3; then compound 4.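

Across this assay, the steps of a 6.8-fold higher number from compound 2 to compound 4 (0.83 log units; beyond the scatter) and a 2.7-fold higher number from compound 3 to compound 4 (0.43 log units; beyond the scatter) and a 9.9-fold higher number from compound 1 to compound 4 (1.00 log units; beyond the scatter) all lie beyond the scatter and place compound 4 above every other compound shown. Going by these compounds alone, the pendant aryl at this position thus spans a wider range than the halogen-bearing rings alone showed, and 3-hydroxyphenyl is the only one of these rings with a hydrogen-bond donor and acceptor. Nothing at hand gives a cause for this rise. On these data alone, whether it follows the hydroxyl itself or its place on the ring stays open. A 4-hydroxyphenyl, 3-methoxyphenyl or 3-aminophenyl on the same chain would separate these readings.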